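Trifluoromethyl to methoxy in a growth-inhibiting series

This account rests on a few compounds, and the source may have more. Where it says the series, first, only, none or still open, it means among the compounds named here.

Compound 1 `COc1cc(-c2ccc(-c3ccc(-c4nc5cc(C)ccc5[nH]4)cc3)cc2)cc(OC)c1OC` gives 190 nM
Compound 2 `FC(F)(F)c1ccc(-c2ccc(-c3ccc(-c4nc5ccccc5[nH]4)cc3)cc2)cc1` gives 33900 nM
Compound 3 `Oc1cccc2[nH]c(-c3ccc(-c4ccc(-c5ccc(C(F)(F)F)cc5)cc4)cc3)nc12` gives 3410 nM

In a functional assay on COLO 205 cells (Homo sapiens) for inhibition, read by sulforhodamine B assay (a higher number here means a weaker inhibitor of growth, a lower number a stronger inhibitor of growth), compound 3 holds the middle place of the three numbers, lower than compound 2 and higher than compound 1. Compound 4 `COc1ccc(-c2ccc(-c3ccc(-c4nc5c(O)cccc5[nH]4)cc3)cc2)cc1` has methoxy in place of trifluoromethyl on an aromatic carbon, para to a large group methoxy in place of trifluoromethyl on an aromatic carbon and is still unmeasured. Among the compounds with values here, the one measured step of a 9.9-fold lower number from compound 2 to compound 3 (1.00 log units; beyond the scatter) is hydroxy in place of hydrogen and so does not test this swap. Compound 1 at 190 nM also carries methoxy but differs in further places, so it offers only a weak hint of a modest drop. The expected step in this assay is a 2.4-fold lower number from compound 3 to compound 4 (0.39 log units; beyond the scatter) and no more than modest. Compound 4 is estimated at 1400 nM with 350 nM to 5000 nM as its expected range.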

Compound 4, concentration for 50% growth inhibition: 1630 nM
Compound 4: the middle estimate sits 1.2-fold (0.07 log units) below what was measured; the range from low to high includes it.
By their numbers in this assay, from the lowest: compound 1; then compound 4; then compound 3; then compound 2.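

Within the data shown here, at this position, on an aromatic carbon para to a large group, methoxy in place of trifluoromethyl gives a 2.1-fold lower number from compound 3 to compound 4 (0.32 log units; beyond the scatter) in this assay as the first direct reading of this swap. The position therefore accepts a change of group and growth inhibition improves, but only modestly. Nothing measured here explains the step. As far as these compounds go, an amine, a carboxylic acid or a longer chain such as ethoxy at this position remains open. So does whether the swap gives a similar step in compounds without the hydroxy group of compound 3 and compound 4.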